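Dropping one chloro from the core of compound 1

This account rests on a few compounds, and the source may have more. Where it says the series, first, only, none or still open, it means among the compounds named here.

Measured compounds:
compound 1, `ClCc1ccc(Cn2cnc3nc(Cl)nc(Cl)c32)cc1`, 4570 nM
compound 2, `ClCc1ccccc1Cn1cnc2ncnc(Cl)c21`, 17400 nM

In a functional assay on NCI-H23 cells (Homo sapiens) for cytotoxicity, read by sulforhodamine B assay, with a stated time of 48 h (a higher number here means a weaker inhibitor of growth, a lower number a stronger inhibitor of growth), compound 1 gives 4570 nM, the lower of the two numbers. Compound 2 gives 17400 nM in this assay, a higher number, and the gap lies beyond the scatter of repeated measurements. Among the measured compounds shown here, the two compounds differ in more than one place, so no single step between them can be read.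

Compound 3, `ClCc1ccc(Cn2cnc3ncnc(Cl)c32)cc1`, has not been measured in this assay. It differs from compound 1 by hydrogen in place of chloro on an aromatic carbon. For the measured compounds named here, no measured pair shows this change alone, so its effect is open. The removal of a chloro from the core is expected to give a modestly higher number in this assay, though the step from compound 1 to compound 3, a 1.8-fold higher number from compound 1 to compound 3 (0.24 log units; within the scatter), is estimated with wide uncertainty. Compound 3 is estimated at 8000 nM, with a range from 3000 nM to 25000 nM.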

Compound 3, concentration for total growth inhibition: 30900 nM
Beside the measured number, compound 3's estimate is 3.9-fold (0.59 log units) below it; the whole stated range lies below it.
By their numbers in this assay, from the lowest: compound 1; then compounds 2 and 3 (each within the scatter of the next).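

In this assay, the chloro on the aromatic carbon between two ring nitrogen atoms proves to matter: hydrogen in its place gives a 6.8-fold higher number from compound 1 to compound 3 (0.83 log units; beyond the scatter), the first single change that can be read among these compounds. The step lies beyond the scatter, so the loss of this one heavy atom, with the rest of compound 1 unchanged, is enough to weaken growth inhibition in this assay. Nothing measured here explains why this chloro counts.

The compounds shown leave open whether an amine, a methoxy group or a fluoro on this carbon would behave more like chloro or more like hydrogen. They also leave open whether the same step would appear with the chloromethyl group placed as it is in compound 2.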